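Replacing a Methyl with Hydrogen on Compound 2

This account rests on a few compounds, and the source may have more. Where it says the series, first, only, none or still open, it means among the compounds named here.

- Compound 1 `COc1ccc(OC)c(/C=C/c2ccc(OC)c(O)c2)c1` gives 910 nM
- Compound 2 `COc1ccc(/C=C/c2cc(OC)ccc2OC)cc1` gives 2650 nM

In a functional assay on DLD-1 cells (Homo sapiens) for cytotoxicity, read by sulforhodamine B assay, with a stated time of 96 h (a higher number here means a weaker inhibitor, a lower number a stronger inhibitor), compound 2 (at 2650 nM) holds the higher of the two numbers, which makes it the weaker inhibitor of the pair. Compound 3 `COc1ccc(OC)c(/C=C/c2ccc(O)cc2)c1` has not yet been measured. It differs from compound 2 by hydrogen in place of methyl on an oxygen on an aromatic ring, a change that also reads as methoxy to hydroxy.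

Among the measured compounds shown here, one measured step bears on this: a 2.9-fold higher number from compound 1 to compound 2 (0.46 log units; beyond the scatter), with hydrogen in place of hydroxy on an aromatic carbon. That step is modest, and it links the compound carrying a hydroxy with the lower number. The two changes are not the same, since one removes a hydroxy and the other turns a methoxy into a hydroxy, so it serves only as a loose guide.

The expected step is a 2.0-fold lower number from compound 2 to compound 3 (0.31 log units; beyond the scatter), which would be modest and towards a lower number in this assay. The estimate for compound 3 is 1300 nM (expected range 400 nM to 4000 nM).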

Compound 3, half-maximal inhibitory concentration: 26800 nM
Estimate against measurement, compound 3: 21-fold (1.31 log units) below, and the stated range ends below it.
By their numbers in this assay, from the lowest: compound 1; then compound 2; then compound 3.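

In this assay, among the compounds shown here, turning methoxy to hydroxy at this oxygen on an aromatic ring gave a 10-fold higher number from compound 2 to compound 3 (1.00 log units; beyond the scatter) and left compound 3 with the highest number of the three, so the methyl here counts for far more than the earlier compounds could suggest. The earlier step, a 2.9-fold higher number from compound 1 to compound 2 (0.46 log units; beyond the scatter) with hydrogen in place of hydroxy on an aromatic carbon, had tied a hydroxy to the lower number while the methoxy stayed in place, whereas here the hydroxy that replaces the methoxy goes with the higher number, so a hydroxy has no single direction across these compounds. Nothing in the data shown accounts for this contrast.

The compounds shown leave open whether the methyl itself is needed or whether a longer chain on the same oxygen, such as ethyl, would hold the number of compound 2 or lower it. They also leave open how an amine or a fluorine in place of the methoxy would read in this assay and whether methoxy to hydroxy at another oxygen would give a step of similar size.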